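A few compounds are considered here, and "the series" means these few. Any claim that something is new, unique, unknown or untested is made for them only; others in the source may bear on it.

Compound 3 `Cc1cc(C)cc(C(O)c2cc(Cl)ccc2OCC(=O)Nc2ccc(S(N)(=O)=O)cc2C)c1` stands lowest of the three numbers in an ADME assay on C8166 cells (Homo sapiens) for cytotoxicity, read by MTT assay (a higher number here means that more compound is tolerated, a lower number that less compound is tolerated), though its gaps to compound 1 `Cc1cccc(C(O)c2cc(Cl)ccc2OCC(=O)Nc2ccc(S(N)(=O)=O)cc2C)c1` and to compound 2 `Cc1cc(S(N)(=O)=O)ccc1NC(=O)COc1ccc(Cl)cc1C(O)c1cccc(F)c1` are within the scatter: compound 3 gives 29400 nM, compound 1 gives 33200 nM, and compound 2 gives 37600 nM. Compound 4 `Cc1cc(S(N)(=O)=O)ccc1NC(=O)COc1ccc(Cl)cc1C(O)c1cc(Cl)cc(C#N)c1` carries 3-chloro-5-cyanophenyl in place of 3,5-dimethylphenyl on a saturated chain carbon bound to an aromatic carbon and an oxygen on a saturated carbon. The steps bearing on this position are a 1.3-fold lower number from compound 2 to compound 3 (0.11 log units; within the scatter) and a 1.1-fold higher number from compound 1 to compound 2 (0.05 log units; within the scatter), and a 1.1-fold lower number from compound 1 to compound 3 (0.05 log units; within the scatter) at another place was no larger. Every change so far at the aryl group on the saturated chain carbon has left the number essentially where it was, so the step to compound 4 is expected to be a 1.1-fold higher number from compound 3 to compound 4 (0.02 log units; within the scatter), with no direction beyond the scatter. Compound 4 is therefore estimated at 31000 nM, in the range 15000 nM to 62000 nM.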

Compound 4, half-maximal cytotoxic concentration: 31600 nM
Compound 4: middle estimate off by 1.0-fold (0.01 log units), on the low side; measured number inside the range.
By their numbers in this assay, from the lowest: compounds 3, 4, 1 and 2 (each within the scatter of the next).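

In this assay, the 3-chloro-5-cyanophenyl group stays within the scatter of all three earlier aryl groups (a 1.1-fold higher number from compound 3 to compound 4 (0.03 log units; within the scatter)), (a 1.2-fold lower number from compound 2 to compound 4 (0.08 log units; within the scatter)) and (a 1.1-fold lower number from compound 1 to compound 4 (0.02 log units; within the scatter)). Within the data shown here, the flat picture at this position therefore extends to an aryl group carrying a nitrile and a chlorine, where the earlier compounds had only methyl and fluoro groups. Nothing available explains this lack of change.

Still open, from the compounds shown here alone, is whether an amine or a carboxylic acid on this phenyl ring, or a cyclohexyl ring in its place, would move the number beyond the scatter.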